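This account rests on a few compounds, and the source may have more. Where it says the series, first, only, none or still open, it means among the compounds named here.

Compound 1 `CCC(C(=O)NCc1ccc(C(F)(F)F)nc1N1CCC(C)CC1)c1ccc(NS(C)(=O)=O)c(F)c1` gives 1.6 nM
Compound 2 `CC1CCN(c2nc(C(F)(F)F)ccc2CNC(=O)C(c2ccc(F)cc2)c2ccc(NS(C)(=O)=O)c(F)c2)CC1` gives 3.4 nM
Compound 3 `CS(=O)(=O)Nc1ccc(C(C(=O)NCc2ccc(C(F)(F)F)nc2SC2CCCCC2)c2ccc(F)cc2)cc1F` gives 37.6 nM

All three were measured in an assay on CHO cells for antagonist activity at transient receptor potential cation channel subfamily V member 1 (Homo sapiens), read by FLIPR; on this read-out higher numbers stand for weaker inhibition and lower numbers for stronger inhibition. Compound 3 stands at the highest number of the three, with an 11-fold higher number from compound 2 to compound 3 (1.04 log units; beyond the scatter) and a yet wider gap to compound 1. Compound 4 `Cc1ccc(CC(C(=O)NCc2ccc(C(F)(F)F)nc2SC2CCCCC2)c2ccc(NS(C)(=O)=O)c(F)c2)cc1` differs from compound 3 in one place: 4-methylbenzyl in place of 4-fluorophenyl on a saturated chain carbon bound to an aromatic carbon and a carbonyl carbon. Within the data shown here, the only measured step at this carbon is a 2.1-fold higher number from compound 1 to compound 2 (0.33 log units; beyond the scatter), a modest one, and no measured pair shows 4-methylbenzyl at that place. A modest step in this assay is therefore expected, in either direction, and not confidently beyond the scatter. Compound 4 is estimated at 45 nM, within 15 nM to 140 nM, which means an expected 1.2-fold higher number from compound 3 to compound 4 (0.08 log units; within the scatter).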

Compound 4, inhibition constant: 40.3 nM
For compound 4 the middle estimate is 1.1-fold (0.05 log units) above the measured one; measured number inside the range.
By their numbers in this assay, from the lowest: compound 1; then compound 2; then compounds 3 and 4 (each within the scatter of the next).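

In this assay, putting 4-methylbenzyl in place of 4-fluorophenyl gives a 1.1-fold higher number from compound 3 to compound 4 (0.03 log units; within the scatter) and so leaves the number unchanged within the scatter, whereas the earlier step at this carbon, a 2.1-fold higher number from compound 1 to compound 2 (0.33 log units; beyond the scatter), lay beyond it. With cyclohexylsulfanyl on the core, this saturated chain carbon therefore accepts either aromatic group equally well. Nothing available explains why the two groups read alike.

On these data alone, it remains open whether an amine or a carboxylic acid would be accepted at this carbon. As far as these compounds go, whether 4-methylbenzyl also matches 4-fluorophenyl with 4-methylpiperidin-1-yl on the core is equally open.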